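The source may report more compounds than this note shows. Statements on the series, on what has been measured and on what is new or still open speak of the compounds shown alone.

Measured so far, in a functional assay on MCF7 cells (Homo sapiens) for antiproliferative activity, read by MTT assay, with a stated time of 48 h; on this read-out higher numbers stand for weaker inhibition and lower numbers for stronger inhibition:

- compound 1, `Cc1ccc(-c2nnc(NC(=O)/C=C/c3ccc(C(F)(F)F)cc3)s2)cc1`, gives 1.1 ug/mL
- compound 2, `O=C(/C=C/c1ccc(C(F)(F)F)cc1)Nc1nnc(-c2ccccc2)s1`, gives 1.52 ug/mL
- compound 3, `O=C(/C=C/c1ccccc1)Nc1nnc(-c2ccccc2)s1`, gives 1.47 ug/mL

The three numbers lie close together. Going from compound 2 to compound 3, the change is hydrogen in place of trifluoromethyl on an aromatic carbon, and the step is a 1.0-fold lower number from compound 2 to compound 3 (0.01 log units; within the scatter). Going from compound 2 to compound 1, the change is methyl in place of hydrogen on an aromatic carbon, and the step is a 1.4-fold lower number from compound 2 to compound 1 (0.14 log units; within the scatter). The unmeasured compound 4, `Cc1ccc(-c2nnc(NC(=O)/C=C/c3ccccc3)s2)cc1`, is made from compound 3 by the same change: methyl in place of hydrogen on an aromatic carbon. The place of the change is the same word for word in both cases, so this is the same change on a different core; the two cores differ by hydrogen in place of trifluoromethyl on an aromatic carbon.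

Among the compounds with values here, since the one earlier instance of this change, from compound 2 to compound 1, moved the number only within the scatter, compound 4 is expected to sit near compound 3, with a step of about a 1.2-fold lower number from compound 3 to compound 4 (0.09 log units; within the scatter). The estimate rests on the step of a 1.4-fold lower number from compound 2 to compound 1 (0.14 log units; within the scatter) and on the value of compound 3, 1.47 ug/mL. Compound 4 is therefore expected to give about 1.2 ug/mL in this assay, most likely between 0.6 ug/mL and 2.4 ug/mL.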

Compound 4, half-maximal inhibitory concentration: 1.19 ug/mL
The estimate for compound 4 lay 1.0-fold (0.00 log units) above the measured number; low and high end bracket the measured number.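

In this assay, the change from phenyl to 4-methylphenyl gives a 1.2-fold lower number from compound 3 to compound 4 (0.09 log units; within the scatter), and the same change on the core carrying trifluoromethyl agrees with it: the same change on two cores in this assay, a 1.4-fold lower number (0.14 log units; within the scatter) from compound 2 to compound 1 and a 1.2-fold lower number (0.09 log units; within the scatter) from compound 3 to compound 4, 1.1-fold (0.05 log units) apart, within the scatter of two such steps. Putting hydrogen in place of trifluoromethyl gives a 1.1-fold higher number from compound 1 to compound 4 (0.03 log units; within the scatter), and this step also agrees with its earlier counterpart: the same change on two cores in this assay, a 1.0-fold lower number (0.01 log units; within the scatter) from compound 2 to compound 3 and a 1.1-fold higher number (0.03 log units; within the scatter) from compound 1 to compound 4, 1.1-fold (0.05 log units) apart, within the scatter of two such steps. Within the data shown here, each change therefore behaves alike on these two cores, but every step lies within the scatter, so this shows only that neither change had a measurable effect here, not that a real effect carries from one core to another, and two cores cannot speak for the rest of the series.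

The compounds shown leave open whether any group at this place can move the number beyond the scatter, for instance an amine or a carboxylic acid in place of the methyl. If such a group did, it would also become possible to test whether a clear step, rather than a step within the scatter, carries across cores.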